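Anilino replacing 4-methylphenyl on the ester-free carbonyl carbon

This account rests on a few compounds, and the source may have more. Where it says the series, first, only, none or still open, it means among the compounds named here.

Measured compounds:
Compound 1 `COc1cccc(C(=O)Oc2cc3c(cc2C)[C@@H](C(C)C)CC=C3C)c1` gives 16.3%
Compound 2 `CC1=CC[C@H](C(C)C)c2cc(C)c(OC(=O)c3ccc(C)cc3)cc21` gives 49.6%
Compound 3 `Cc1cc2c(C(C)C)ccc(C)c2cc1OC(=O)c1cccc(C(F)(F)F)c1` gives 26.7%

In a functional assay on PC-3 cells (Homo sapiens) for antiproliferative activity, read by sulforhodamine B assay, with a stated time of 48 h, tested at 50 uM (on this read-out higher numbers stand for more inhibition at the one concentration tested (going by the name of the read-out) and lower numbers for less inhibition), compound 2 stands highest of the three, with compound 3 the nearest and compound 1 the furthest below it, both gaps beyond the scatter. The step from compound 2 to compound 4 `CC1=CC[C@H](C(C)C)c2cc(C)c(OC(=O)Nc3ccccc3)cc21` changes the group on the carbonyl carbon: anilino in place of 4-methylphenyl on a carbonyl carbon. Among the measured compounds shown here, the one measured step at this same position is a number 33.3 percentage points higher from compound 1 to compound 2 (beyond the scatter), which shows that exchanging the group on the carbonyl carbon can move this assay by a large amount. For the measured compounds named here, no measured compound carries an anilino group, and compound 3, whose differences from compound 2 lie elsewhere, gives no guidance on the direction. The change is therefore expected to matter beyond the scatter, but its direction is uncertain, and the estimate is placed below compound 2, covering a wide span. Compound 4 is expected to give 35% in this assay, between 10% and 60%, an expected step of a number 14.6 percentage points lower from compound 2 to compound 4 (beyond the scatter).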

Compound 4, a percentage reported as inhibition, at one concentration (the size of the read-out at that concentration, not a potency): 93.2%
Compound 4: middle estimate off by 58.2 percentage points, on the low side, outside the stated range (above it).
By their numbers in this assay, from the lowest: compound 1; then compound 3; then compound 2; then compound 4.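

In this assay the group on the carbonyl carbon turns out to reach much further than the two aryl groups suggested, with a number 43.6 percentage points higher from compound 2 to compound 4 (beyond the scatter) and, against the 3-methoxyphenyl group, a number 76.9 percentage points higher from compound 1 to compound 4 (beyond the scatter). The leaving and entering groups have the same count of heavy atoms and the same aromatic ring, so in this pair a large rise accompanies an exchange that differs in a nitrogen and its hydrogen-bond donor. Nothing available here accounts for the rise.

The compounds shown leave open whether the rise depends on the amide hydrogen or on the phenyl ring, which an N-methylanilino or a cyclohexylamino group at this place would separate. They also leave open whether ring substituents on the anilino group, as in 4-methylanilino or 4-methoxyanilino, would give a higher, lower or level number in this assay.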